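The source may hold more compounds than are shown below. What is called first, only, known or untested is meant among the compounds shown, and "the series" means these compounds.

Measured compounds:
compound 1 `NC(=O)Cn1c(=O)n(C2OC(CO)[C@@H](O)[C@H]2O)c2nc(N)nc(O)c21` with 42%
compound 2 `C=CCn1c(=O)n(C2CN(C(c3ccccc3)c3ccccc3)CC(CO)O2)c2nc(N)nc(O)c21` with 46%
compound 3 `Cn1c(=O)n2c3c1c(=O)nc(N)n3CC1OC2[C@H](O)[C@@H]1O` with 6%

All three share a core and were tested in a functional assay on YAC-1 cells (Mus musculus); on this read-out lower numbers stand for smaller maximal responses and higher numbers for larger maximal responses. Compound 1 gives 42%, which is the second highest of the three numbers. Its nearest neighbour is compound 2 with 46%; that gap is within the scatter of repeated measurements, so the two cannot be told apart. Its furthest neighbour is compound 3 with 6%, a much lower maximal response that lies beyond the scatter. Compound 3 is the one whose core is closed into an extra ring, which sets it apart from the other two in structure as well as in number.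

The step of interest leads from compound 1 to compound 4 `N#Cc1ccc(Cn2c(=O)n(C3OC(CO)[C@@H](O)[C@H]3O)c3nc(N)nc(O)c32)cc1`, which has not yet been measured in this assay. The change is this: 4-cyanophenyl in place of carbamoyl on a saturated chain carbon bound to an aromatic nitrogen. For the measured compounds named here, nothing among the measured pairs differs in one place, so no counted step shows what such a swap does. Compounds 1 and 2, which differ at this same chain carbon and elsewhere, give numbers within the scatter of each other, which hints that the group at this position need not move the response much.

The expectation for compound 4 is therefore a step of a number 3 percentage points higher from compound 1 to compound 4 (within the scatter), small and of uncertain direction, likely within the scatter. Compound 4 is estimated at 45%, with a range from 22% to 68%.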

Compound 4, largest response reached (reported as maximal response), in percent of the reference or control that the assay uses: 0%
Beside the measured number, compound 4's estimate is 45 percentage points above it, and the stated range ends above it.
By their numbers in this assay, from the lowest: compounds 4 and 3 (each within the scatter of the next); then compounds 1 and 2 (each within the scatter of the next).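

Putting 4-cyanophenyl in place of carbamoyl on a saturated chain carbon bound to an aromatic nitrogen gives a number 42 percentage points lower from compound 1 to compound 4 (beyond the scatter) in this assay. The earlier compounds shown here offered no comparison that differed in one place, and this first direct reading shows that the position is far from indifferent: this one change on the shared core is enough to take the maximal response of compound 1 down to the level of compound 4, where 0% is recorded. The swap removes the carbamoyl group with its hydrogen-bond donor and brings in an aromatic ring and a nitrile together, and no measurement shown links the fall to any one of these parts or gives a reason for it.

From the compounds shown here alone, it remains open whether the aromatic ring, the nitrile or the loss of carbamoyl matters most, and a plain phenyl group at the same place would separate the first two. It is also unknown how a carboxylic acid, an amine or a longer chain on that carbon would fare, so a single step cannot show how the response varies across groups at this position.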